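Acetamido in place of chloro on the chain carbon

A few compounds are considered here, and "the series" means these few. Any claim that something is new, unique, unknown or untested is made for them only; others in the source may bear on it.

Three coumarin-carbonyl compounds have been tested in a functional assay on HT-1080 cells (Homo sapiens), read by transwell migration, with a stated time of 24 h, tested at 1 uM; a higher number here means a weaker effect of the compound at the concentration tested, a lower number a stronger effect. Compound 3 `O=C(Oc1cccc(Cl)c1)c1cc2cc(CCl)ccc2oc1=O` gives 79.8%, the highest number of the three, so the weakest effect at this concentration. Compound 1 `CC(=O)OCc1ccc2oc(=O)c(C(=O)Nc3cccc(Cl)c3)cc2c1` gives 66.9% in this assay, and compound 2 `CC(C)C(=O)OCc1ccc2oc(=O)c(C(=O)Oc3cccc(Br)c3)cc2c1` gives 37.8%, both beyond the scatter below compound 3. Compound 4 `CC(=O)NCc1ccc2oc(=O)c(C(=O)Oc3cccc(Cl)c3)cc2c1` has not yet been measured. It differs from compound 3 in one place: acetamido in place of chloro on a saturated chain carbon bound to an aromatic carbon. Among the measured compounds shown here, no single-change step between measured compounds exists to guide the size of this change, so the expectation rests on the spread of the three numbers alone. A modest fall in the number, toward a stronger effect, is expected, a number 17.8 percentage points lower from compound 3 to compound 4 (beyond the scatter). Compound 4 is therefore estimated at 62%, with a range from 38% to 86% in this assay.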

Compound 4, a percentage reported as activity, at one concentration (the size of the read-out at that concentration, not a potency): 36.6%
The estimate for compound 4 lay 25.4 percentage points above the measured number; the measured number lies below the stated range.
By their numbers in this assay, from the lowest: compounds 4 and 2 (each within the scatter of the next); then compound 1; then compound 3.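

In this assay, among the compounds shown here, the first single-change reading at this position shows that the saturated chain carbon bound to an aromatic carbon is sensitive to what it carries: acetamido in place of chloro gives a number 43.2 percentage points lower from compound 3 to compound 4 (beyond the scatter) as a large step toward a stronger effect. The data shown offer no measurement that accounts for the size of this step.

Going by these compounds, it remains open whether the step needs the whole acetamido group, since an amine on the same chain carbon, or an amide with a longer chain, would separate its parts. On these data alone, it is also open whether the step would hold on another compound.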